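Trimming the Amine on a Kinase-Inhibitor Scaffold

The source may hold more compounds than are shown below. What is called first, only, known or untested is meant among the compounds shown, and "the series" means these compounds.

Of the compounds shown here, two have so far been measured in an assay on isolated protein for inhibition of Rho-associated protein kinase 2 (Homo sapiens), read by ELISA, with a stated time of 30 min, in the presence of a further agent that is not named here; a higher number here means a weaker inhibitor, a lower number a stronger inhibitor. Compound 1 `CN(C)C(=O)Cc1sc(NC(=O)C2COc3ccccc3O2)nc1-c1ccncc1` gives 8830 nM in this assay. Compound 2 `O=C(Nc1nc(-c2cccnc2)c(CN2CCCC2)s1)C1COc2ccccc2O1` gives 1560 nM in this assay, which is the lower of the two numbers; the gap between compound 2 and compound 1 is wider than the scatter of repeated runs. These two structures differ in more than one place. Their values are set side by side without being read as a single step.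

Compound 3 `CN(C)Cc1sc(NC(=O)C2COc3ccccc3O2)nc1-c1cccnc1` has not yet been measured. It differs from compound 2 in one place only: dimethylamino in place of pyrrolidin-1-yl on a saturated chain carbon bound to an aromatic carbon. Everything else in the molecule stays the same. Exchanging one small amine for another at the same carbon gives no reason, on the numbers shown, to expect a move beyond the usual scatter in either direction. Compound 3 is therefore estimated to give about 2200 nM in this assay, with a plausible range from 900 nM to 5500 nM. The step this estimate implies, a 1.4-fold higher number from compound 2 to compound 3 (0.15 log units; within the scatter), is expected to stay within the scatter.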

Compound 3, half-maximal inhibitory concentration: 4960 nM
Estimate against measurement, compound 3: 2.3-fold (0.35 log units) below; the range from low to high includes it.
By their numbers in this assay, from the lowest: compound 2; then compounds 3 and 1 (each within the scatter of the next).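

In this assay, among these compounds, the exchange of pyrrolidin-1-yl for dimethylamino on a saturated chain carbon bound to an aromatic carbon gives the first comparison here that differs in one place only: a 3.2-fold higher number from compound 2 to compound 3 (0.50 log units; beyond the scatter). The step is modest, but it shows that this position does not treat these two small amines as interchangeable, even though both have the same count of hydrogen-bond donors and acceptors and neither carries a net charge. Nothing measured here explains the move, so the reason for the difference remains unknown.

The change removes the ring and two heavy atoms at once, so the compounds shown leave open whether the ring, the size of the group or something else accounts for the step; diethylamino, an open-chain amine, and azetidin-1-yl, a smaller ring, could begin to separate these possibilities. They also leave open whether a larger ring such as piperidin-1-yl or morpholin-4-yl would extend the step in the same direction, and whether the same exchange would have a similar effect on a different core.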